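The source may hold more compounds than are shown below. What is called first, only, known or untested is meant among the compounds shown, and "the series" means these compounds.

Measured compounds:
compound 1 `CCCOc1ccc(-c2cc(=O)c3c(o2)C(CC)(CC)C(=O)C(CC)=C3O)cc1` — > 50.5 uM
compound 2 `CCC1=C(O)c2c(oc(-c3ccccc3C)cc2=O)C(CC)(CC)C1=O` — 40.9 uM

Among the compounds with values here, compound 2 gives 40.9 uM in a functional assay on KB cells (Homo sapiens) for antiproliferative activity, read by sulforhodamine B assay, with a stated time of 3 days (a lower number here means that less compound is needed, a higher number that more compound is needed for the effect), the only number so far. Compound 1 reaches only > 50.5 uM in this assay, which is a limit and not a number. Within the data shown here, the one further value is that limit (the limit of > 50.5 uM in this assay, at which 1 of the 2 values shown sits).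

Compound 3 `CCC1=C(O)c2c(oc(-c3cc(C)ccc3F)cc2=O)C(CC)(CC)C1=O` differs from compound 2 by 2-fluoro-5-methylphenyl in place of 2-methylphenyl on an aromatic carbon. Among the measured compounds shown here, no step between measured compounds is available here, so the expected step of a 1.0-fold lower number from compound 2 to compound 3 (0.01 log units; within the scatter) is taken as none beyond the scatter. Compound 3 is estimated at 40 uM, with a range from 15 uM to 100 uM.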

Compound 3, concentration for half-maximal effect: 47.3 uM
Compound 3: the middle estimate sits 1.2-fold (0.07 log units) below what was measured; measured number inside the range.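

Replacing 2-methylphenyl with 2-fluoro-5-methylphenyl on the aromatic carbon next to the ring oxygen gives a 1.2-fold higher number from compound 2 to compound 3 (0.06 log units; within the scatter) in this assay, so this position accepts both added substituents without a step beyond the scatter. No measured property shown bears on this step.

Compound 1 gives > 50.5 uM, which is a limit and not a number, so steps to it cannot be read. From the compounds shown here alone, whether an amine or a carboxylic acid on this phenyl ring would move the number beyond the scatter remains open.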